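Shifting a Chlorine Atom on a Piperidine Amide Series

The source may hold more compounds than are shown below. What is called first, only, known or untested is meant among the compounds shown, and "the series" means these compounds.

The measured compounds are:
compound 1, `O=C1COc2ccc(NC(=O)C3CCN(c4cccc(Cl)c4)CC3)cc2N1`, giving 190 nM in a functional assay for antagonist activity at transient receptor potential cation channel subfamily V member 1 (Homo sapiens), read by FLIPR and calcium flux; on this read-out lower numbers stand for stronger inhibition and higher numbers for weaker inhibition;
compound 2, `CC(=O)N1CCc2ccc(NC(=O)C3CCN(c4cccc(C(F)(F)F)c4)CC3)cc21`, giving 800 nM in this assay;
compound 3, `O=C(Nc1cnc2ccccc2c1)C1CCN(c2cccc(C(F)(F)F)c2)CC1`, giving 600 nM in this assay.

Compound 1 holds the lowest of the three numbers. Its nearest neighbour is compound 3, whose value lies beyond the scatter above it, and its furthest is compound 2, also beyond the scatter. Among the measured compounds shown here, no two of the measured compounds differ in a single place, so no single-point step is available for comparison.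

Compound 4, `O=C1COc2ccc(NC(=O)C3CCN(c4ccccc4Cl)CC3)cc2N1`, differs from compound 1 by 2-chlorophenyl in place of 3-chlorophenyl on an amine nitrogen in a ring. The measured compounds say nothing directly about this kind of change, since they differ from one another in several places at once. In the absence of a guiding step, a moderate weakening is expected, somewhat beyond the scatter but not by a large margin, with the direction itself uncertain. For compound 4 the expected value in this assay is 600 nM, estimated to lie between 200 nM and 2500 nM. This estimate means an expected step of a 3.2-fold higher number from compound 1 to compound 4 (0.50 log units; beyond the scatter).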

Compound 4, half-maximal inhibitory concentration: 220 nM
The estimate for compound 4 lay 2.7-fold (0.44 log units) above the measured number; measured number inside the range.
By their numbers in this assay, from the lowest: compounds 1 and 4 (each within the scatter of the next); then compounds 3 and 2 (each within the scatter of the next).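

In this assay, among the compounds shown here, 2-chlorophenyl in place of 3-chlorophenyl on an amine nitrogen in a ring gives a 1.2-fold higher number from compound 1 to compound 4 (0.06 log units; within the scatter), the first comparison here that changes one place only. The two placements of the chlorine therefore cannot be told apart on this read-out, which compounds 1, 2 and 3 could not show, as they differ from one another in several places at once. No supporting data bear on why these two compounds read alike.

Going by these compounds, whether the same holds for a group other than chlorine at this position, such as a methoxy group or a nitrile, remains open. Also open, on these data alone, is how the trifluoromethyl group carried by compounds 2 and 3 would compare with chlorine on the core of compound 1.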